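This account rests on a few compounds, and the source may have more. Where it says the series, first, only, none or still open, it means among the compounds named here.

Measured in a functional assay on KMS-11 cells (Homo sapiens) for antiproliferative activity, read by CellTiter-Glo, with a stated time of 72 h; on this read-out higher numbers stand for weaker inhibition and lower numbers for stronger inhibition:
- Compound 1 `COc1ccc(C(=O)N(Cc2ccncc2)Cc2cccc(OCCc3cccc(C(F)(F)F)c3)c2)cc1`: 8900 nM
- Compound 2 `COc1ccc(C(=O)N(Cc2ccncc2)Cc2cccc(OCc3ccc(F)cc3)c2)cc1`: 22700 nM
- Compound 3 `COc1ccc(C(=O)N(Cc2ccncc2)Cc2cccc(OCC(=O)c3cccc(Br)c3)c2)cc1`: 18700 nM

The numbers show a 1.2-fold lower number from compound 2 to compound 3 (0.08 log units; within the scatter) and a 2.1-fold higher number from compound 1 to compound 3 (0.32 log units; beyond the scatter), so compound 3 sits in the higher pair. Compound 4 `COc1ccc(C(=O)N(Cc2ccncc2)Cc2cccc(OCc3cccc([N+](=O)[O-])c3)c2)cc1` carries 3-nitrophenyl in place of (3-bromophenyl)carbonyl on a saturated chain carbon bound to an oxygen on an aromatic ring. At this same place, the measured changes gave a 2.6-fold higher number from compound 1 to compound 2 (0.41 log units; beyond the scatter) and, closest to the present change, a 1.2-fold lower number from compound 2 to compound 3 (0.08 log units; within the scatter). The latter step links 4-fluorophenyl and (3-bromophenyl)carbonyl, so no step beyond the scatter is expected in this assay. The step expected is a 1.0-fold higher number from compound 3 to compound 4 (0.01 log units; within the scatter). The estimate for compound 4 is 19000 nM, with an expected range from 9500 nM to 38000 nM.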

Compound 4, half-maximal inhibitory concentration: 19600 nM
Compound 4: the middle estimate sits 1.0-fold (0.01 log units) below what was measured; the measured number falls inside the stated range.
By their numbers in this assay, from the lowest: compound 1; then compounds 3, 4 and 2 (each within the scatter of the next).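

In this assay, swapping in 3-nitrophenyl gives a 1.0-fold higher number from compound 3 to compound 4 (0.02 log units; within the scatter) and a 1.2-fold lower number from compound 2 to compound 4 (0.06 log units; within the scatter), so a third, differently built group at this saturated chain carbon reads the same as the previous two. The one gap here remains the one to the 3-(trifluoromethyl)benzyl group, now also seen as a 2.2-fold higher number from compound 1 to compound 4 (0.34 log units; beyond the scatter). No evidence is at hand to explain this level response. Open, as far as these compounds go, is whether that gap follows the trifluoromethyl group or the longer chain. Also open, from the compounds shown here alone, is whether an amine or a carboxylic acid at this place would shift the number.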